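Acetyl to piperidinyl on the fused ring of compound 3

A few compounds are considered here, and "the series" means these few. Any claim that something is new, unique, unknown or untested is made for them only; others in the source may bear on it.

Three compounds carry a number in an assay on CHO cells for displacement of a labelled ligand from Substance-P receptor (Homo sapiens); a lower number here means a stronger inhibitor, a higher number a weaker inhibitor. Compound 1 `COc1ccccc1N1CCN(C(=O)CCc2c(-c3ccc(Cl)cc3)[nH]c3ccccc23)CC1` gives 31 nM in this assay, and compound 2 `COc1ccccc1N1CCN(C(=O)CCc2c(-c3ccccc3)[nH]c3ccc(Cl)cc23)CC1` gives 5.6 nM. Compound 3 `CC(=O)c1ccc2c(c1)c(CCC(=O)N1CCC(O)(Cc3ccccc3)CC1)c(-c1ccc(Cl)cc1)n2C` stands lowest of the three with 0.19 nM, beyond the scatter from both, and the gap to compound 1 is the widest in the set. Compound 1 and compound 2 differ in more than one place from compound 3, so their pair says only what the two values show.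

Compound 4 `Cn1c(-c2ccc(Cl)cc2)c(CCC(=O)N2CCC(O)(Cc3ccccc3)CC2)c2cc(N3CCCCC3)ccc21` is not yet measured in this assay. It differs from compound 3 by piperidin-1-yl in place of acetyl on an aromatic carbon, meta to a fused ring and para to a fused ring of the two-ring system. Going by the values given here, no measured pair in the set walks this same change, so nothing in the data fixes its size or direction. Given that compound 3 already sits at 0.19 nM, the step from compound 3 to compound 4 is expected to be small, within or only slightly beyond the scatter, and on the side of a weaker inhibitor. The estimate for compound 4 in this assay is 0.5 nM, with a range from 0.1 nM to 3 nM, meaning an expected step of a 2.6-fold higher number from compound 3 to compound 4 (0.42 log units; beyond the scatter).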

Compound 4, half-maximal inhibitory concentration: 3.3 nM
Beside the measured number, compound 4's estimate is 6.6-fold (0.82 log units) below it; measured number above the stated range.
By their numbers in this assay, from the lowest: compound 3; then compounds 4 and 2 (each within the scatter of the next); then compound 1.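

In this assay, going by these compounds alone, piperidin-1-yl in place of acetyl on this aromatic carbon, meta to a fused ring and para to a fused ring, gives a 17-fold higher number from compound 3 to compound 4 (1.24 log units; beyond the scatter), a large step and the first single change that can be read, showing that the value responds strongly to the group at this position. Each group counts as 1 hydrogen-bond acceptor and 0 hydrogen-bond donors, and neither has a net charge, so these counts do not separate the pair; the differences counted are the six-membered non-aromatic ring with 1 hetero atom, the nitrogen in place of oxygen, and the loss of the double bond outside aromatic rings. No measurement at hand bears on what lies behind the step.

Still open, from the compounds shown here alone, is whether the step follows from losing the acetyl or from bringing in the piperidine ring; an open-chain dimethylamino group, a morpholin-4-yl ring or a nitrile at this carbon would help separate the two. Within the data shown here, also open is whether the same exchange has a similar size on a different amide side chain, such as the one carried by compound 1.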